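A few compounds are considered here, and "the series" means these few. Any claim that something is new, unique, unknown or untested is made for them only; others in the source may bear on it.

Two hydroxamic acids built on one chain with a urea link open this set: compound 1 `O=C(CCCCCONC(=O)Nc1cnc2ccccc2c1)NO` and compound 2 `COc1cc(NC(=O)NOCCCCCC(=O)NO)c2ncccc2c1`. In an assay on cells for inhibition of histone deacetylase 4 (Homo sapiens), read by fluorescence (on this read-out higher numbers stand for weaker inhibition and lower numbers for stronger inhibition), compound 1 reaches only a limit of the assay, > 10000 nM, and no number. In this assay compound 2 also stops at a limit, > 10000 nM, without a number. Compound 2 thus stands where every value shown stands, because both sit at the limit of > 10000 nM in this assay, at which 2 of the 2 values shown sit. Compound 3 `COc1cc(NC(=O)NOCCCCCC(=O)NO)c2nccc(C)c2c1` has not yet been measured; it differs from compound 2 in one place, (methyl in place of hydrogen on an aromatic carbon). For the measured compounds named here, no measured pair shows what such a change does in this assay, so the step from compound 2 to compound 3 is expected to bring no movement beyond the scatter, in neither direction, a step that the limit leaves unreadable from compound 2 to compound 3. Compound 3 is therefore expected to give about 20000 nM, somewhere between 5000 nM and 80000 nM, most likely again reported only as a limit.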

Compound 3, half-maximal inhibitory concentration: > 10000 nM
Compound 3: no number, only a limit; the forecaster's own chance of this, stated with the estimate: 85%; the middle value does not contradict the limit.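

The step from compound 2 to compound 3 cannot be read, because both compounds stop at a limit: the limit of > 10000 nM in this assay, at which 3 of the 3 values shown sit. With no number among them, the compounds shown leave open how strongly any of them inhibits in this assay and what methyl in place of hydrogen on an aromatic carbon does there.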